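The source may hold more compounds than are shown below. What is called first, only, known or untested is meant among the compounds shown, and "the series" means these compounds.

Compound 1 `CC(CC(=O)/N=C(\N)NCCCc1ccc(CN(C)C)o1)c1ccccc1` gives 3020 nM in an assay on ileum for antagonist activity at histamine H1 receptor (Cavia porcellus), with a stated time of 15 min; a higher number here means weaker binding, a lower number tighter binding. Compound 2 `CC(CC(=O)/N=C(\N)NCCCc1cn[nH]c1)c1ccccc1` gives 3800 nM in this assay.

Of these two numbers, compound 2 has the higher one, yet compound 1 sits within the scatter of it, so the two cannot be told apart. Compound 3 `CC(CC(=O)/N=C(\N)NCCCc1ncn[nH]1)c1ccccc1` differs from compound 2 by 1H-1,2,4-triazol-5-yl in place of 1H-pyrazol-4-yl on a saturated chain carbon, three bonds along the chain from an amine nitrogen. For the measured compounds named here, the one step that bears on this, a 1.3-fold higher number from compound 1 to compound 2 (0.10 log units; within the scatter), also exchanged the ring at that same place and stayed within the scatter. A step of similar size, with no direction beyond the scatter, is expected here, a 1.1-fold higher number from compound 2 to compound 3 (0.02 log units; within the scatter). Compound 3 is therefore estimated at 4000 nM, with a range from 1500 nM to 11000 nM.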

Compound 3, dissociation constant: 1480 nM
The estimate for compound 3 lay 2.7-fold (0.43 log units) above the measured number; the whole stated range lies above it.
By their numbers in this assay, from the lowest: compound 3; then compounds 1 and 2 (each within the scatter of the next).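

Replacing 1H-pyrazol-4-yl with 1H-1,2,4-triazol-5-yl gives a 2.6-fold lower number from compound 2 to compound 3 (0.41 log units; beyond the scatter) and replacing 5-((dimethylamino)methyl)furan-2-yl with it gives a 2.0-fold lower number from compound 1 to compound 3 (0.31 log units; beyond the scatter) in this assay and both steps are modest but beyond the scatter. So the ring on this saturated chain carbon can change binding, which the earlier exchange between compound 1 and compound 2 could not show. Still open, on these data alone, is whether a 1H-imidazol-4-yl ring or a longer chain at this place would tighten binding further. Nothing available explains why the 1H-1,2,4-triazol-5-yl ring gives the lower number.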